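Replacing the Cyanophenyl Arm on a Shared Core

The compounds below may be only part of what the source reports. "The series", "measured", "known", "first", "only" and "open" are said of these compounds alone.

Measured compounds:
Compound 1 `CC/C(=C(/c1ccc(/C=C/C(=O)O)cc1)c1cc2ccccc2[nH]1)c1ccccc1C#N` gives 9 nM
Compound 2 `CC/C(=C(/c1ccc(/C=C/C(=O)O)cc1)c1cc2ccccc2[nH]1)c1ccccc1OC(F)(F)F` gives 206 nM
Compound 3 `CC/C(=C(/c1ccc(/C=C/C(=O)O)cc1)c1cc2ccccc2[nH]1)c1ccc(F)cc1Cl` gives 39 nM

In a functional assay on MCF7 cells (Homo sapiens) for inhibition (on this read-out higher numbers stand for weaker inhibition and lower numbers for stronger inhibition), compound 1 stands lowest of the three, beyond the scatter from both others. Compound 4 `CC/C(=C(/c1ccc(/C=C/C(=O)O)cc1)c1cc2ccccc2[nH]1)c1ccc(Cl)c(C)c1` differs from it in one place: 4-chloro-3-methylphenyl in place of 2-cyanophenyl on a double-bonded chain carbon bound to a double-bonded chain carbon and a saturated chain carbon. For the measured compounds named here, two measured steps bear on this change: a 23-fold higher number from compound 1 to compound 2 (1.36 log units; beyond the scatter) and a 4.3-fold higher number from compound 1 to compound 3 (0.64 log units; beyond the scatter). Both remove the cyano group, and both gave higher numbers, one large and one modest. The entering 4-chloro-3-methylphenyl likewise carries no cyano group, so a rise beyond the scatter is expected, probably between those two sizes; the expected step is a 6.7-fold higher number from compound 1 to compound 4 (0.82 log units; beyond the scatter). Compound 4 is therefore estimated at 60 nM, in a range from 15 nM to 250 nM.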

Compound 4, half-maximal inhibitory concentration: 840 nM
Compound 4: the middle estimate sits 14-fold (1.15 log units) below what was measured, and the stated range ends below it.
By their numbers in this assay, from the lowest: compound 1; then compound 3; then compound 2; then compound 4.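

At this position, the replacement ring matters as well as the loss of the nitrile: compound 3 and compound 4 both carry a chlorinated phenyl, yet a 22-fold higher number from compound 3 to compound 4 (1.33 log units; beyond the scatter) separates them. The earlier high end is also passed, with a 4.1-fold higher number from compound 2 to compound 4 (0.61 log units; beyond the scatter) on this read-out, and the whole swap gives a 93-fold higher number from compound 1 to compound 4 (1.97 log units; beyond the scatter) in all. Nothing available here explains these differences.

Still open, as far as these compounds go, is whether the chloro or the methyl group drives this result, and whether an amine or a carboxylic acid on the ring would stay close to compound 1.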